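A few compounds are considered here, and "the series" means these few. Any claim that something is new, unique, unknown or untested is made for them only; others in the source may bear on it.

Measured so far:
Compound 1 `COc1cc2cc(C(=O)CCCCC3CC[N+](C)(Cc4ccccc4)CC3)sc2cc1OC` — in a physicochemical assay for solubility (on this read-out lower numbers stand for lower solubility and higher numbers for higher solubility), compound 1 gives 1000 ug/mL.
Compound 2 `C=CC[n+]1ccc(CCC(=O)c2cc3cc(OC)c(OC)cc3s2)cc1` — in this assay compound 2 gives 25000 ug/mL.

Compound 2 stands at the higher of the two numbers; compound 1 lies well beneath it, and the gap between the two is beyond the scatter. Among the compounds with values here, no pair of measured compounds differs in only one place, so the two values mark the spread of the series and nothing more.

Compound 3 `CCOCC[n+]1ccc(CCC(=O)c2cc3cc(OC)c(OC)cc3s2)cc1` is not yet measured. It differs from compound 2 in one place: ethoxymethyl in place of vinyl on a saturated chain carbon bound to an aromatic nitrogen. Within the data shown here, no measured pair isolates a change of this kind, so there is no step to lean on. For this assay the expectation is a step of no size beyond the scatter, and the estimate for compound 3 is written as no change at the digits printed from compound 2 to compound 3 (within the scatter). Compound 3 is therefore expected to give 25000 ug/mL, with a range from 10000 ug/mL to 60000 ug/mL.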

Compound 3, solubility: 50000 ug/mL
Estimate against measurement, compound 3: 2.0-fold (0.30 log units) below; measured number inside the range.
By their numbers in this assay, from the lowest: compound 1; then compounds 2 and 3 (each within the scatter of the next).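

Within the data shown here, this position, on a saturated chain carbon bound to an aromatic nitrogen, now has its first readable step: in this assay, ethoxymethyl in place of vinyl gives a 2.0-fold higher number from compound 2 to compound 3 (0.30 log units; within the scatter) and stays the only single-place comparison. The double bond of vinyl can therefore go and an ether oxygen can enter at this place with no separation of compound 2 and compound 3 on this read-out. The available data offer nothing that accounts for this result.

As far as these compounds go, whether a group of another kind at this place, such as an amine or a carboxylic acid, would also stay within the scatter remains open. One step at one place also leaves open how a longer chain there, or any change elsewhere in the shared core, would read.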